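This account rests on a few compounds, and the source may have more. Where it says the series, first, only, none or still open, it means among the compounds named here.

Measured compounds:
- compound 1, `c1ccc([C@@H]2CCC[C@H](CCNCC3CCCCC3)O2)cc1`, 2.4 nM
- compound 2, `CN(C)CC[C@H]1CCC[C@@H](c2ccccc2)O1`, 217 nM
- compound 3, `c1ccc([C@H]2CCC[C@@H](CCN3CCCC3)O2)cc1`, 60 nM

All three compounds share a core made of a saturated oxygen ring bearing a phenyl group and a short chain that ends in a basic amine. They were compared in an assay on membranes from brain for displacement of a labelled ligand from Sigma non-opioid intracellular receptor 1 (Cavia porcellus), read by scintillation counting, with a stated time of 120 min; a higher number here means a weaker inhibitor, a lower number a stronger inhibitor. Compound 3, with its pyrrolidin-1-yl group, stands second highest of the three numbers: compound 2 gives a higher number, and the gap between them lies beyond the usual scatter, while compound 1 gives a far lower number, also beyond the scatter. For the measured compounds named here, no single-point step between any two measured compounds has been computed, so their values can only be set side by side.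

Compound 4, `CN(C)CC[C@@H]1CCC[C@H](c2ccccc2)O1`, has not yet been measured in this assay. It differs from compound 3 by dimethylamino in place of pyrrolidin-1-yl on a saturated chain carbon, two bonds along the chain from a saturated ring carbon. Compound 2 also carries a dimethylamino group on its chain and gives the highest number of the three, which suggests that this smaller amine is tolerated less well than the pyrrolidin-1-yl or cyclohexylmethylamino groups. Compound 4 is therefore expected to give a weaker result than compound 3, with a step of a 2.5-fold higher number from compound 3 to compound 4 (0.40 log units; beyond the scatter) that reaches beyond the scatter. The estimate for compound 4 in this assay is 150 nM, with a range from 50 nM to 500 nM.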

Compound 4, inhibition constant: 465 nM
For compound 4 the middle estimate is 3.1-fold (0.49 log units) below the measured one; low and high end bracket the measured number.
By their numbers in this assay, from the lowest: compound 1; then compound 3; then compound 2; then compound 4.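

In this assay, for the compounds shown here, the earlier compounds could only be set side by side, but putting dimethylamino in place of pyrrolidin-1-yl on a saturated chain carbon, two bonds along the chain from a saturated ring carbon, can now be read as a single change: a 7.8-fold higher number from compound 3 to compound 4 (0.89 log units; beyond the scatter). At this position, then, the open dimethylamino group gives a clearly weaker inhibitor than the five-membered pyrrolidin-1-yl ring, a link that the scattered amines of the first three compounds could only hint at. Amine choice is also not the only thing that counts, as the drawn configuration alone gives a 2.1-fold higher number from compound 2 to compound 4 (0.33 log units; beyond the scatter), a modest step that still lies beyond the scatter and that can be read cleanly for one reason: the fact that compounds 2 and 4 differ only in the configuration as drawn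

The compounds shown leave open how the mirror image of compound 3 would compare, and so whether the change of amine has the same size in both configurations. Also open, from the compounds shown here alone, is how a piperidin-1-yl or morpholin-4-yl group, or a longer chain carrying the amine, would compare with pyrrolidin-1-yl and dimethylamino.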